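Methoxy pattern changes and Vero cell cytotoxicity

This account rests on a few compounds, and the source may have more. Where it says the series, first, only, none or still open, it means among the compounds named here.

Compound 1 `COC(=O)c1cc(-c2cccc(NC(=O)c3ccc(/C=C/C(=O)c4ccccc4OC)cc3)c2)on1`, compound 2 `COC(=O)c1cc(-c2cccc(NC(=O)c3ccc(/C=C/C(=O)c4ccc(OC)cc4OC)cc3)c2)on1` and compound 3 `COC(=O)c1cc(-c2cccc(NC(=O)c3ccc(/C=C/C(=O)c4cccc(OC)c4)cc3)c2)on1` share a core and differ only in the methoxy pattern on the ring attached to the carbonyl carbon. All three were tested in an ADME assay on Vero cells (Chlorocebus sabaeus) for cytotoxicity, read by MTT assay, with a stated time of 72 h; on this read-out higher numbers stand for lower toxicity in this test and lower numbers for higher toxicity in this test. Compound 1 gave only a limit of the assay, > 40 ug/mL. Compound 2 likewise gave only a limit, > 50 ug/mL. Compound 3 also gave only a limit, > 100 ug/mL. Because every reading is a limit, the sizes of the steps cannot be read: a step that the two limits leave unreadable from compound 1 to compound 2, a step that the two limits leave unreadable from compound 1 to compound 3 and a step that the two limits leave unreadable from compound 2 to compound 3. The change from compound 1 to compound 2 is methoxy in place of hydrogen on an aromatic carbon. The cores of compound 1 and compound 3 differ as follows: 3-methoxyphenyl in place of 2-methoxyphenyl on a carbonyl carbon. Compound 4 `COC(=O)c1cc(-c2cccc(NC(=O)c3ccc(/C=C/C(=O)c4ccc(OC)c(OC)c4)cc3)c2)on1` has not yet been measured in this assay. It arises from compound 3 by methoxy in place of hydrogen on an aromatic carbon; the methoxy enters ortho rather than meta to a methoxy group, so this is the same kind of change as from compound 1 to compound 2, not the same. Since compound 3 sits at a limit, > 100 ug/mL, and the earlier step left no readable size, compound 4 is expected to show little change, a number no higher from compound 3 to compound 4 (the limit leaves the size open). The estimate for compound 4 is 100 ug/mL, between 40 ug/mL and 250 ug/mL.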

Compound 4, half-maximal cytotoxic concentration: > 50 ug/mL
Compound 4 ended at the assay's limit; the forecaster's own chance of this, stated with the estimate: 80%; the middle value does not contradict the limit.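

Among the compounds shown here, compound 4 gave only a limit in this assay, as did compound 1, compound 2 and compound 3, so no step from any of these three to compound 4 can be read. The compounds shown leave open the actual cytotoxic concentration of each compound, and whether changing the methoxy pattern alters it at all.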